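A few compounds are considered here, and "the series" means these few. Any claim that something is new, unique, unknown or untested is made for them only; others in the source may bear on it.

Compound 1 `COc1ccc(OC)c(S(=O)(=O)NC2=NCCN2C(=S)SN2CCn3c2nsc3=S)c1` carries a 2,5-dimethoxyphenyl group on the sulfonyl sulfur of the shared core. In a functional assay on KYSE-510 cells (Homo sapiens) for antiproliferative activity, read by crystal violet staining, with a stated time of 96 h (a higher number here means a weaker inhibitor of growth, a lower number a stronger inhibitor of growth), compound 1 gives >= 20000 nM, which is a limit of the assay rather than a number. Compound 2 `O=S(=O)(NC1=NCCN1C(=S)SN1CCn2c1nsc2=S)c1ccc(-c2ccccc2)cc1` is a second member of the series. In this assay compound 2 gives >= 20000 nM, again only a limit. Compound 3 `O=S(=O)(NC1=NCCN1C(=S)SN1CCn2c1nsc2=S)c1ccc(Oc2ccccc2)cc1` completes the measured set. In this assay compound 3 gives >= 20000 nM, once more a limit. Going by the values given here, the single step between measured compounds cannot be sized, because a step that the two limits leave unreadable from compound 2 to compound 3 runs between two limits. What the measured set does show is the limit of >= 20000 nM in this assay, at which 3 of the 3 values shown sit, so no aryl group tried so far has given a readable growth inhibition.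

Compound 4 `O=S(=O)(NC1=NCCN1C(=S)SN1CCn2c1nsc2=S)c1ccc2ccccc2c1` is the next analogue, and it differs from compound 1 by naphthalen-2-yl in place of 2,5-dimethoxyphenyl on a sulfonyl sulfur. Among the compounds with values here, no measured step bears directly on this exchange, and the one available step is unreadable, so the expectation rests only on the position of compound 1 and its neighbours at the limit. Compound 4 is therefore expected to sit near the same limit, estimated at 20000 nM with a range from 8000 nM to 50000 nM. This estimate means an expected step of a number no higher from compound 1 to compound 4 (the limit leaves the size open), that is, none beyond the scatter.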

Compound 4, concentration for 50% growth inhibition: >= 20000 nM
Compound 4 gave a limit, no number; the forecaster's own chance of this, stated with the estimate: 70%; the middle value sits exactly at the limit.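

In this assay compound 1 and compound 4 both stand only at a limit of the assay, so the step from one to the other cannot be read and naphthalen-2-yl cannot be ranked against 2,5-dimethoxyphenyl. The compounds shown leave open whether any group on the sulfonyl sulfur of the shared core gives a readable growth inhibition.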